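Butyl in Place of Isopropyl on a Sulfur

This account rests on a few compounds, and the source may have more. Where it says the series, first, only, none or still open, it means among the compounds named here.

In a functional assay on HeLa cells (Homo sapiens) for cytotoxicity (a higher number here means a weaker inhibitor, a lower number a stronger inhibitor), compound 1 `CC1=CCC[C@H]2[C@](C)(CC3=CC(=O)C=CC3=O)[C@@H](C)CC[C@]12C` gives 26800 nM. Compound 2 `CC1=CCC[C@H]2[C@](C)(CC3=CC(=O)C(SC(C)C)=CC3=O)[C@@H](C)CC[C@]12C` gives 67000 nM, the higher of the two numbers. For the measured compounds named here, the only measured step, a 2.5-fold higher number from compound 1 to compound 2 (0.40 log units; beyond the scatter), comes with isopropylsulfanyl in place of hydrogen on a double-bonded ring carbon. Compound 3 `CCCCSC1=CC(=O)C(C[C@]2(C)[C@@H](C)CC[C@]3(C)C(C)=CCC[C@@H]23)=CC1=O` differs from compound 2 in one place: butyl in place of isopropyl on a sulfur, with butyl in place of isopropyl on a sulfur. Going by the values given here, the measured step adds the whole isopropylsulfanyl group and is modest, and no measured pair varies the chain on the sulfur, so it bears on this change only indirectly. No step beyond the scatter is therefore expected in this assay, and no direction is favoured with confidence. Compound 3 is estimated at 55000 nM, with an expected range of 22000 nM to 130000 nM. This estimate means an expected 1.2-fold lower number from compound 2 to compound 3 (0.09 log units; within the scatter).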

Compound 3, half-maximal inhibitory concentration: 25100 nM
Compound 3: middle estimate off by 2.2-fold (0.34 log units), on the high side, within the range that was stated.
By their numbers in this assay, from the lowest: compounds 3 and 1 (each within the scatter of the next); then compound 2.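

In this assay the chain on the sulfur turns out to matter, which the earlier pair could not show: the change from isopropyl to butyl gives a 2.7-fold lower number from compound 2 to compound 3 (0.43 log units; beyond the scatter) and so is a step of about the same size as the one that added the isopropylsulfanyl group. Adding the sulfur with a chain therefore does not by itself set the number, since isopropylsulfanyl gave a 2.5-fold higher number from compound 1 to compound 2 (0.40 log units; beyond the scatter) while butylsulfanyl gives a 1.1-fold lower number from compound 1 to compound 3 (0.03 log units; within the scatter) and leaves compound 3 level with compound 1. Nothing available here explains why the two chains differ.

With only these two chains on the sulfur, the compounds shown leave open whether the effect follows chain length or branching. Going by these compounds, it also remains open what a longer chain such as hexyl, or a chain ending in an amine or a carboxylic acid, would do at this place.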